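Cinnamoyl amide series: swapping the acyl group on compound 2

A few compounds are considered here, and "the series" means these few. Any claim that something is new, unique, unknown or untested is made for them only; others in the source may bear on it.

Two amides of the shared core have been run so far. In a functional assay on MCF7 cells (Homo sapiens) for cytotoxicity, read by MTT assay, with a stated time of 48 h (a higher number here means a weaker inhibitor, a lower number a stronger inhibitor), compound 1 `CCCCCCCCNC(=O)[C@@H](NC(=O)/C=C/c1ccccc1)[C@@H](C)O` gives 35100 nM. Compound 2 `CCCCCCCCCCCCCCNC(=O)[C@@H](NC(=O)c1nccc2ccccc12)[C@@H](C)O` gives 22800 nM in this assay, the lower of the two numbers; the gap to compound 1 is within the scatter, so no order between them can be read.

Compound 3 `CCCCCCCCCCCCCCNC(=O)[C@@H](NC(=O)/C=C/c1ccccc1)[C@@H](C)O` differs from compound 2 in one place: 2-phenylethenyl in place of isoquinolin-1-yl on a carbonyl carbon. The same 2-phenylethenyl acyl group is present in compound 1, whose value in this assay sits close to that of compound 2, so the data give no sign that this acyl group moves the number by much. For the measured compounds named here, no measured pair isolates this change, and the expectation rests on the closeness of compound 1 and compound 2 alone.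

For compound 3 the estimated step from compound 2 is a 1.2-fold higher number from compound 2 to compound 3 (0.09 log units; within the scatter), that is, no change beyond the scatter is expected. Compound 3 is therefore estimated at 28000 nM in this assay, within a range of 12000 nM to 65000 nM.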

Compound 3, half-maximal inhibitory concentration: 64600 nM
Compound 3: the middle estimate sits 2.3-fold (0.36 log units) below what was measured; the range from low to high includes it.
By their numbers in this assay, from the lowest: compounds 2, 1 and 3 (each within the scatter of the next, the first and the last beyond it).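

For the compounds shown here, this is the first measured pair that isolates the acyl group: in this assay, 2-phenylethenyl in place of isoquinolin-1-yl on a carbonyl carbon gives a 2.8-fold higher number from compound 2 to compound 3 (0.45 log units; beyond the scatter) and so shows that the group at this place can move the number, though only modestly. The second new pair isolates the chain: hexyl in place of hydrogen on a saturated chain carbon, eight bonds along the chain from an amide-type nitrogen, gives a 1.8-fold higher number from compound 1 to compound 3 (0.26 log units; within the scatter) and so leaves no order to read between compound 1 and compound 3. Nothing at hand bears on the reason for either step.

Going by these compounds alone, still open is whether the acyl step seen on the chain of compound 3 carries over to the shorter chain of compound 1, since only one pair speaks for it. Also open, as far as these compounds go, is how a saturated 2-phenylethyl group on the same carbonyl carbon would compare with 2-phenylethenyl, and whether a chain longer than that of compound 3 would give a step beyond the scatter.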